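Working notes: from compound 2 to compound 3

The source may hold more compounds than are shown below. What is called first, only, known or untested is meant among the compounds shown, and "the series" means these compounds.

Measured in a functional assay on A549 cells (Homo sapiens) for antiproliferative activity, read by MTT assay, with a stated time of 72 h; on this read-out higher numbers stand for weaker inhibition and lower numbers for stronger inhibition:
- compound 1 `CC(C)NC(=N)NC(=N)Nc1ccc(F)c(F)c1`: 5200 nM
- compound 2 `CCN(CC)C(=N)NC(=N)Nc1ccc(F)c(F)c1`: 7800 nM

For the measured compounds named here, only these two compounds have numbers so far, and compound 2, at 7800 nM, lies within the scatter of compound 1. The next compound is compound 3 `N=C(NC(=N)NC1CCCC1)Nc1ccc(F)c(F)c1`, which carries cyclopentylamino in place of diethylamino on a carbon with a double bond to nitrogen.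

Going by the values given here, one measured step bears on this change: a 1.5-fold higher number from compound 1 to compound 2 (0.18 log units; within the scatter). It involves a group on the same kind of carbon and stays within the scatter. Among the compounds with values here, no measured compound carries cyclopentylamino, so this single step is thin support and the range is kept wide. No change beyond the scatter is expected in this assay. The expected step is a 1.6-fold lower number from compound 2 to compound 3 (0.19 log units; within the scatter). For compound 3 the estimate is 5000 nM, with an expected range of 2200 nM to 11000 nM.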

Compound 3, half-maximal inhibitory concentration: 3500 nM
Beside the measured number, compound 3's estimate is 1.4-fold (0.15 log units) above it; low and high end bracket the measured number.
By their numbers in this assay, from the lowest: compounds 3, 1 and 2 (each within the scatter of the next, the first and the last beyond it).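

In this assay, the group on the carbon with a double bond to nitrogen now gives a step beyond the scatter (a 2.2-fold lower number from compound 2 to compound 3 (0.35 log units; beyond the scatter)), with cyclopentylamino in place of diethylamino, though the step is modest. Cyclopentyl in place of isopropyl on an amine nitrogen stays within the scatter (a 1.5-fold lower number from compound 1 to compound 3 (0.17 log units; within the scatter)), so these two groups are not told apart here, and only compound 2 and compound 3 separate among the three compounds. The change to compound 3 replaces a group with no ring and 0 hydrogen-bond donors by one with a five-membered ring and 1 hydrogen-bond donor, but no available evidence says which difference, if either, accounts for the step.

Open, as far as these compounds go, is whether cyclohexyl, phenyl or a longer chain on this amine nitrogen would give a step beyond the scatter from compound 1. Also open, from the compounds shown here alone, is whether a hydroxyl group on the cyclopentyl ring would keep the number of compound 3.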